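The source may report more compounds than this note shows. Statements on the series, on what has been measured and on what is new or still open speak of the compounds shown alone.

Measured compounds:
- compound 1 `CCN1CCN(CC(=O)Nc2ccc(-c3nc(-c4ccccc4)c(-c4ccccc4)n3C)cc2)CC1`: 38.6%
- compound 2 `Cc1ccc(CN2CCN(CC(=O)Nc3ccc(-c4nc(-c5ccccc5)c(-c5ccccc5)n4C)cc3)CC2)cc1`: 31.5%

Within the data shown here, in a functional assay on MCF7 cells (Homo sapiens) for cytotoxicity, read by MTT assay, with a stated time of 24 h, tested at 32 ug/mL (a lower number here means a weaker effect, a higher number a stronger effect of the compound at the concentration tested), compound 2 gives the lower of the two numbers, but the only measured step, a number 7.1 percentage points lower from compound 1 to compound 2 (within the scatter), stays within the scatter, so the two compounds cannot be ranked. Compound 3 `Cn1c(-c2ccc(NC(=O)CN3CCN(Cc4ccc(Cl)cc4)CC3)cc2)nc(-c2ccccc2)c1-c1ccccc1` differs from compound 2 by chloro in place of methyl on an aromatic carbon. Among the measured compounds shown here, no measured step exchanges a chloro for a methyl on an aromatic carbon, so there is no direct guide; the one known step was small. The expected step is therefore a number 4.5 percentage points higher from compound 2 to compound 3 (within the scatter), none beyond the scatter. Compound 3 is estimated at 36%, ranging from 22% to 52%.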

Compound 3, a percentage reported as activity, at one concentration (the size of the read-out at that concentration, not a potency): 52.8%
Beside the measured number, compound 3's estimate is 16.8 percentage points below it; measured number outside the range, above it.
By their numbers in this assay, from the lowest: compounds 2 and 1 (each within the scatter of the next); then compound 3.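

In this assay, among these compounds, chloro in place of methyl on this aromatic carbon gives a number 21.3 percentage points higher from compound 2 to compound 3 (beyond the scatter), the first step beyond the scatter, so exchanging this one heavy atom changes the read-out. The 4-chlorobenzyl group also stands clear of the ethyl group, with a number 14.2 percentage points higher from compound 1 to compound 3 (beyond the scatter), although the 4-methylbenzyl group did not. Nothing available explains this difference.

From the compounds shown here alone, whether the rise is specific to chloro remains open, as fluoro, bromo or methoxy at this place could tell. A read-out at one concentration also leaves potency unknown.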